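A Shared Acetylation Step Carried to a Second Core

This account rests on a few compounds, and the source may have more. Where it says the series, first, only, none or still open, it means among the compounds named here.

Three compounds measured in an ADME assay on HEK-293T cells (Homo sapiens) for cytotoxicity, read by MTT assay, tested at 100 uM (on this read-out higher numbers stand for a weaker effect at the one concentration tested and lower numbers for a stronger effect), share a nitrothiazole amide and differ in the substituted phenol attached to it. Compound 1, `COc1ccc(O)c(C(=O)Nc2ncc([N+](=O)[O-])s2)c1`, gives 100% in this assay. Compound 2, `COc1ccc(OC(C)=O)c(C(=O)Nc2ncc([N+](=O)[O-])s2)c1`, gives 94.1% in this assay. The step of a number 5.9 percentage points lower from compound 1 to compound 2 (within the scatter) arises from acetyl in place of hydrogen on an oxygen on an aromatic ring, and it leaves the two numbers within the usual scatter of each other, so the acetylation of compound 1 did not change its read-out in a measurable way. Compound 3, `CC(C)c1cc(C(=O)Nc2ncc([N+](=O)[O-])s2)c(O)c(C(C)C)c1`, gives 7.1% in this assay, the lowest of the three numbers and the strongest effect at the one concentration tested. How the core of compound 3 differs from the core of compound 1 is not broken down here.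

Compound 4, `CC(=O)Oc1c(C(=O)Nc2ncc([N+](=O)[O-])s2)cc(C(C)C)cc1C(C)C`, is not yet measured in this assay. It differs from compound 3 by acetyl in place of hydrogen on an oxygen on an aromatic ring, the same change that turned compound 1 into compound 2. The expectation for compound 4 rests on that earlier step: because a number 5.9 percentage points lower from compound 1 to compound 2 (within the scatter) stayed within the scatter, the step is estimated to be small here as well, namely a number 2.9 percentage points higher from compound 3 to compound 4 (within the scatter). On that basis compound 4 is expected to give about 10% in this assay, with a likely range from 2% to 30%, staying close to the value of compound 3. Going by the values given here, whether the acetyl group behaves alike on both cores is, with only two examples, an open question.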

Compound 4, a percentage reported as activity, at one concentration (the size of the read-out at that concentration, not a potency): 20.6%
Compound 4: the middle estimate sits 10.6 percentage points below what was measured; measured number inside the range.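

On the core of compound 3, hydroxy to acetoxy brings a number 13.5 percentage points higher from compound 3 to compound 4 (beyond the scatter) in this assay, which here means a weaker effect at the one concentration tested, whereas on the core of compound 1 the same change brought a number 5.9 percentage points lower from compound 1 to compound 2 (within the scatter). Going by these compounds alone, the change therefore did not carry over from one core to the other with the same size of step: the same change on two cores in this assay, a number 5.9 percentage points lower (within the scatter) from compound 1 to compound 2 and a number 13.5 percentage points higher (beyond the scatter) from compound 3 to compound 4, 19.4 percentage points apart, beyond the scatter of two such steps This shows that, in these two pairs, the outcome of the acetylation depended on the core it was made on, but with only two pairs it establishes no rule for the series, and it does not show which of the differences between the two cores accounts for the gap, nor why the gap arises.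

The compounds shown leave open whether a longer acyl chain, such as butanoyl, in place of acetyl on the same oxygen would follow the step seen on the core of compound 1 or the one seen on the core of compound 3. They also leave open whether a simple methyl ether on that oxygen, which carries no carbonyl, would behave like the acetoxy compounds or like the free hydroxy compounds on either core.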